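This account rests on a few compounds, and the source may have more. Where it says the series, first, only, none or still open, it means among the compounds named here.

Working notes on the shared core, tested in a functional assay on HeLa cells (Homo sapiens) for cytotoxicity, in the presence of a further agent that is not named here; on this read-out higher numbers stand for weaker inhibition and lower numbers for stronger inhibition.

Compound 1 `Clc1ccc(-c2cc(-c3ccsc3)nc(-c3ccco3)c2)o1` returns only a limit, > 50000 nM, and is the compound sitting at the limit of > 50000 nM in this assay, at which 1 of the 2 values shown sits. Compound 2 `Clc1ccc(-c2cc(-c3cccnc3)nc(-c3cccs3)c2)o1` gives 14600 nM in this assay. Going by the values given here, this is the only number in the set, so compound 2 cannot be placed above or below anything measured.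

Compound 3 `Clc1ccc(-c2cc(-c3ccco3)nc(-c3cccs3)c2)o1` is not yet measured. It differs from compound 2 by furan-2-yl in place of pyridin-3-yl on an aromatic carbon. Among the compounds with values here, no pair of measured compounds differing in one place exists, so the size of this step cannot be read from the data. Compound 1, which also carries furan-2-yl, shows only the limit > 50000 nM. The expectation for the step from compound 2 to compound 3 is a weakening beyond the scatter, a 2.7-fold higher number from compound 2 to compound 3 (0.44 log units; beyond the scatter). Compound 3 is thus estimated at 40000 nM, with a range from 12000 nM to 150000 nM, and a substantial chance of a limit only.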

Compound 3, half-maximal inhibitory concentration: 18800 nM
Estimate against measurement, compound 3: 2.1-fold (0.33 log units) above; the range from low to high includes it.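

In this assay, the aromatic carbon next to the ring nitrogen accepts either of two aromatic rings without a change that can be read: a 1.3-fold higher number from compound 2 to compound 3 (0.11 log units; within the scatter), so furan-2-yl and pyridin-3-yl are not told apart at this position. Going by these compounds alone, the attachment point of the thiophene ring does register, with thiophen-2-yl in place of thiophen-3-yl giving an at least 2.6-fold lower number from compound 1 to compound 3 (0.42 log units; beyond the scatter), the first step that lies beyond the scatter. Compound 1 remains a limit rather than a number, so this step has a lower bound but no upper end: the limit of > 50000 nM in this assay, at which 1 of the 3 values shown sits.

Open, as far as these compounds go, is whether the thiophene step keeps its size with pyridin-3-yl as the partner group, and what an amine or a carboxylic acid would do at the carbon holding furan-2-yl in compound 3. The 5-chlorofuran-2-yl group is the same in all three compounds, so its contribution cannot be read.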